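Chloro to methylsulfanyl on the methyl-bearing core

The source may hold more compounds than are shown below. What is called first, only, known or untested is meant among the compounds shown, and "the series" means these compounds.

Measured so far:
compound 1, `CSc1ccc(Cc2nn(C(C)(C)C)c(=O)c3ccccc23)cc1`, in a functional assay on aorta with Alpha-1D adrenergic receptor (Rattus norvegicus) as the target (a lower number here means that less compound is needed, a higher number that more compound is needed for the effect), gives only a limit of the assay, > 100000 nM.
compound 2, `CC(C)(C)n1nc(Cc2ccc(Cl)cc2)c2ccccc2c1=O`, in this assay gives only a limit of the assay, > 100000 nM.
compound 3, `Cn1nc(Cc2ccc(Cl)cc2)c2ccccc2c1=O`, in this assay gives 430 nM.

Among the compounds with values here, two of the three values sit at the limit of > 100000 nM in this assay, at which 2 of the 3 values shown sit, so they are limits and not numbers; compound 3 carries the only number in this set. The two cores differ as methyl in place of tert-butyl on an aromatic nitrogen, and that change gives an at least 230-fold lower number from compound 2 to compound 3 (2.36 log units; beyond the scatter). Between compound 2 and compound 1 the change is methylsulfanyl in place of chloro on an aromatic carbon; the step there is a step that the two limits leave unreadable from compound 2 to compound 1.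

Compound 4, `CSc1ccc(Cc2nn(C)c(=O)c3ccccc23)cc1`, is not yet measured in this assay. It differs from compound 3 by methylsulfanyl in place of chloro on an aromatic carbon, the same change as from compound 2 to compound 1, at the same place. The earlier step gives no readable size, so the expectation rests on compound 3 with its value 430 nM and on the change itself. The expected step is a 1.4-fold higher number from compound 3 to compound 4 (0.14 log units; within the scatter). Compound 4 is estimated at 600 nM, expected to fall between 150 nM and 3000 nM.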

Compound 4, half-maximal effective concentration: 930 nM
The estimate for compound 4 lay 1.6-fold (0.19 log units) below the measured number, and the stated range covers the measured number.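

In this assay, methylsulfanyl in place of chloro on the core of compound 3 gives a 2.2-fold higher number from compound 3 to compound 4 (0.34 log units; beyond the scatter), while the same change on the core of compound 2 cannot be read, since both compounds on that core are limits and not numbers: the limit of > 100000 nM in this assay, at which 2 of the 4 values shown sit. This change therefore has only one readable size, and the compounds shown cannot tell whether it carries over from one core to the other at the same size or even in the same direction. Methyl in place of tert-butyl on the aromatic nitrogen gives an at least 100-fold lower number from compound 1 to compound 4 (2.03 log units; beyond the scatter), so that change lowers the number on both the chloro and the methylsulfanyl compounds, but whether its size differs between them stays open: the same change on two cores in this assay, an at least 230-fold lower number (2.36 log units; beyond the scatter) from compound 2 to compound 3 and an at least 100-fold lower number (2.03 log units; beyond the scatter) from compound 1 to compound 4; the limit leaves it open whether they differ.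

Groups on the aromatic nitrogen other than methyl and tert-butyl, such as ethyl or a longer chain, remain open. So do other groups in place of chloro, such as methoxy or an amine.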